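This account rests on a few compounds, and the source may have more. Where it says the series, first, only, none or still open, it means among the compounds named here.

Compound 3 `Cc1ccc(CNC(=O)c2nn(-c3ccc(F)cc3)c(OC[C@@H](O)C[C@@H](O)CC(=O)O)c2C(C)C)cc1` gives 15 nM in an assay on microsomes from liver for inhibition of 3-hydroxy-3-methylglutaryl-coenzyme A reductase (Rattus norvegicus) (a lower number here means a stronger inhibitor, a higher number a weaker inhibitor), the highest of the three numbers seen so far. Compound 1 `Cc1ccc(CNC(=O)c2nn(-c3ccc(F)cc3)c(CC[C@@H](O)C[C@@H](O)CC(=O)O)c2C(C)C)cc1` gives 2.5 nM and compound 2 `CC(C)c1c(C(=O)N(C)Cc2cccc(F)c2)nn(-c2ccc(F)cc2)c1CC[C@@H](O)C[C@@H](O)CC(=O)O` gives 4.1 nM. The gap a 6.0-fold higher number from compound 1 to compound 3 (0.78 log units; beyond the scatter) comes from a change on the other side of the shared core, not the part altered here. Compound 4 `CC(C)c1c(C(=O)NCc2cccc(Cl)c2)nn(-c2ccc(F)cc2)c1OC[C@@H](O)C[C@@H](O)CC(=O)O` differs from compound 3 by 3-chlorophenyl in place of 4-methylphenyl on a saturated chain carbon bound to an amide-type nitrogen. Among the measured compounds shown here, the one measured step that touches the same region is a 1.6-fold higher number from compound 1 to compound 2 (0.21 log units; within the scatter), which exchanged one benzylamide for another and stayed within the scatter. No step beyond the scatter is therefore expected, so compound 4 is expected to stay close to that number, with an expected step of no change at the digits printed from compound 3 to compound 4 (within the scatter). The estimate for compound 4 is 15 nM, ranging from 6 nM to 40 nM.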

Compound 4, half-maximal inhibitory concentration: 5.4 nM
For compound 4 the middle estimate is 2.8-fold (0.44 log units) above the measured one; measured number outside the range, below it.
By their numbers in this assay, from the lowest: compounds 1, 2 and 4 (each within the scatter of the next, the first and the last beyond it); then compound 3.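

This position is not silent: a 2.8-fold lower number from compound 3 to compound 4 (0.44 log units; beyond the scatter) lies beyond the scatter, whereas the earlier exchange of one benzylamide for another, a 1.6-fold higher number from compound 1 to compound 2 (0.21 log units; within the scatter), stayed within it. The entering 3-chlorophenyl and the leaving 4-methylphenyl have the same counts of heavy atoms, rings, hydrogen-bond donors and acceptors, so those counts do not separate them. No measurement here accounts for the shift. From the compounds shown here alone, it remains open whether the chlorine or its place on the ring carries the step, which 4-chlorophenyl and 3-methylphenyl would separate. Also open, going by these compounds, is whether the same swap matters on the 6-carboxy-3,5-dihydroxyhexyl chain of compound 1.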